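Swapping a methoxy group for a hydroxyl on the aryl ring

This account rests on a few compounds, and the source may have more. Where it says the series, first, only, none or still open, it means among the compounds named here.

Of the compounds shown here, three sharing one core have been tested in a functional assay on MCF7 cells (Homo sapiens) for antiproliferative activity, read by MTT assay, with a stated time of 72 h (on this read-out higher numbers stand for weaker inhibition and lower numbers for stronger inhibition), so far. Compound 1 `O=C1O/C(=C\Cn2cc(-c3cc(F)cc(F)c3)nn2)C(OCc2ccccc2)=C1OCc1ccccc1` carries a 3,5-difluorophenyl group; in this assay compound 1 sits at the limit of > 100000 nM, a limit of the assay rather than a number. Compound 2 `COc1ccc(-c2cn(C/C=C3\OC(=O)C(OCc4ccccc4)=C3OCc3ccccc3)nn2)cc1` carries a 4-methoxyphenyl group instead and gives 39100 nM, a change of an at least 2.5-fold lower number from compound 1 to compound 2 (0.40 log units; beyond the scatter). Compound 3 `COc1ccccc1-c1cn(C/C=C2\OC(=O)C(OCc3ccccc3)=C2OCc2ccccc2)nn1` carries a 2-methoxyphenyl group; in this assay compound 3 returns > 100000 nM, again a limit rather than a number. This means an at least 2.5-fold higher number from compound 2 to compound 3 (0.40 log units; beyond the scatter), while a step that the two limits leave unreadable from compound 1 to compound 3. Compound 3 therefore stands at the weak end of what has been seen, at the same limit as compound 1 (the limit of > 100000 nM in this assay, at which 2 of the 3 values shown sit).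

Compound 4 `O=C1O/C(=C\Cn2cc(-c3cccc(O)c3)nn2)C(OCc2ccccc2)=C1OCc1ccccc1` is the next compound, with 3-hydroxyphenyl in place of 2-methoxyphenyl on an aromatic carbon. Among the compounds with values here, none of the measured steps involves a hydroxyl group or this position of the ring, so the only guidance is that the one numeric value came from compound 2 and both other aryl groups reached the limit. Compound 4 is therefore expected to land near the limit, with an at least 1.2-fold lower number from compound 3 to compound 4 (0.09 log units; that floor lies within the scatter) as the expected step. The estimate for compound 4 is 80000 nM, with a range from 20000 nM to 300000 nM.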

Compound 4, half-maximal inhibitory concentration: 27800 nM
For compound 4 the middle estimate is 2.9-fold (0.46 log units) above the measured one; the measured number falls inside the stated range.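

Within the data shown here, the 3-hydroxyphenyl group of compound 4 is the first aryl group here with a hydrogen-bond donor, and in this assay it gives a readable number, with an at least 3.5-fold lower number from compound 3 to compound 4 (0.55 log units; beyond the scatter) and an at least 3.5-fold lower number from compound 1 to compound 4 (0.55 log units; beyond the scatter). A methoxy group is therefore not required for a readable number on this aromatic carbon, and the two aryl groups that give readable numbers cannot be told apart, with a 1.4-fold lower number from compound 2 to compound 4 (0.15 log units; within the scatter). The two larger steps are only minimum sizes, as each starts from a compound that rests on a limit: the limit of > 100000 nM in this assay, at which 2 of the 4 values shown sit.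

Among the compounds shown, the methoxy and hydroxyl groups never sit at the same ring position, so the effect of the oxygen group itself cannot be separated from the effect of where it sits on the ring. As far as these compounds go, it also remains open whether an amine or a carboxylic acid in place of the hydroxyl would keep a readable number, and whether any group on this aromatic carbon can give much stronger inhibition than compounds 2 and 4 do.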